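The source may hold more compounds than are shown below. What is called first, only, known or untested is meant among the compounds shown, and "the series" means these compounds.

Compound 1 `CNC(=O)c1cc(Oc2ccc(NC(=O)c3nn(-c4ccccc4OC(F)(F)F)c(=O)cc3C)cc2F)ccn1` and compound 2 `Cc1cc(=O)n(-c2ccc(Br)cc2F)nc1C(=O)Nc1ccc(Oc2ncnc3ccsc23)c(F)c1` share an amide-linked core and were both tested in a functional assay on HepG2 cells (Homo sapiens) for cytotoxicity, read by MTT assay, with a stated time of 72 h; on this read-out higher numbers stand for weaker inhibition and lower numbers for stronger inhibition. Compound 1 gives only a limit there, > 40000 nM. Among the compounds with values here, compound 2 gives 3350 nM, the only actual number among the two values shown. The other value shown, that of compound 1, is a limit, (the limit of > 40000 nM in this assay, at which 1 of the 2 values shown sits). Compound 3 `Cc1cc(=O)n(-c2ccccc2OC(F)(F)F)nc1C(=O)Nc1ccc(Oc2ncnc3ccsc23)c(F)c1` has not yet been measured in this assay. It differs from compound 2 in one place: 2-(trifluoromethoxy)phenyl in place of 4-bromo-2-fluorophenyl on an aromatic nitrogen. Within the data shown here, no measured pair differing only at this group is available, so the size of the step is open. Compound 1, carrying the same 2-(trifluoromethoxy)phenyl, sits at the limit of > 40000 nM in this assay, at which 1 of the 2 values shown sits, but it also differs from compound 2 elsewhere, so this points only loosely toward weaker inhibition. Compound 3 is expected to lose some potency, the estimated step being a 2.4-fold higher number from compound 2 to compound 3 (0.38 log units; beyond the scatter). The estimate for compound 3 in this assay is 8000 nM, within a range from 2500 nM to 40000 nM.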

Compound 3, half-maximal inhibitory concentration: 15700 nM
The estimate for compound 3 lay 2.0-fold (0.29 log units) below the measured number; measured number inside the range.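

In this assay, putting 2-(trifluoromethoxy)phenyl in place of 4-bromo-2-fluorophenyl on the aromatic nitrogen gives a 4.7-fold higher number from compound 2 to compound 3 (0.67 log units; beyond the scatter), the first direct measure of how much this position responds to a change of aryl group. With 2-(trifluoromethoxy)phenyl held fixed, changing the group on the oxygen on an aromatic ring gives an at least 2.5-fold lower number from compound 1 to compound 3 (0.40 log units; beyond the scatter), so the aryl group alone does not set the number. Compound 1 has only a limit, so this second step gives a minimum size and not an exact one: the limit of > 40000 nM in this assay, at which 1 of the 3 values shown sits.

The compounds shown do not separate the contributions of the bromine, the fluorine and the trifluoromethoxy group. On these data alone, how an unsubstituted phenyl, or a phenyl carrying an amine or a carboxylic acid, would behave at this nitrogen remains open.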